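The source may report more compounds than this note shows. Statements on the series, on what has been measured and on what is new or still open speak of the compounds shown alone.

Measured compounds:

Compound 1, `Oc1cccc(-c2cc(-c3ccco3)cc(-c3ccccc3O)n2)c1`, gives 0% in an assay on isolated protein for inhibition of DNA topoisomerase 1 (Homo sapiens), with a stated time of 30 min, tested at 20 uM; a higher number here means a stronger effect of the compound at the concentration tested, a lower number a weaker effect.
Compound 2, `Oc1ccc(-c2cc(-c3ccco3)cc(-c3ccccc3O)n2)cc1`, gives 0% in this assay.
Compound 3, `Oc1cccc(-c2cc(-c3ccco3)cc(-c3cccc(O)c3)n2)c1`, gives 0% in this assay.

All three compounds share a core carrying a furan-2-yl group and two hydroxyphenyl groups, and they differ only in where the hydroxyl sits on those phenyl rings. From compound 1 to compound 2 the change is 4-hydroxyphenyl in place of 3-hydroxyphenyl on an aromatic carbon, and the step is no change at the digits printed from compound 1 to compound 2 (within the scatter). The core of compound 3 differs from that of compound 1 by 3-hydroxyphenyl in place of 2-hydroxyphenyl on an aromatic carbon, with the step of no change at the digits printed from compound 1 to compound 3 (within the scatter). Compound 3 stands level with compound 1 and compound 2 at the digits printed, so none of the three can be called stronger or weaker than another.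

Compound 4, `Oc1ccc(-c2cc(-c3ccco3)cc(-c3cccc(O)c3)n2)cc1`, has not been measured. It differs from compound 3 by 4-hydroxyphenyl in place of 3-hydroxyphenyl on an aromatic carbon. Within the data shown here, this is the same kind of change as the one from compound 1 to compound 2, not the same: in compound 3 the place is meta to a 3-hydroxyphenyl group, whereas in compound 1 it is meta to a 2-hydroxyphenyl group. Because the earlier step of no change at the digits printed from compound 1 to compound 2 (within the scatter) showed no change, and because compound 3 itself gives 0%, the step from compound 3 to compound 4 is expected to be no change at the digits printed from compound 3 to compound 4 (within the scatter). Compound 4 is therefore estimated at 0%, between 0% and 10%.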

Compound 4, a percentage reported as inhibition, at one concentration (the size of the read-out at that concentration, not a potency): 1.5%
Beside the measured number, compound 4's estimate is 1.5 percentage points below it, and the stated range covers the measured number.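

In this assay, 4-hydroxyphenyl in place of 3-hydroxyphenyl gives a number 1.5 percentage points higher from compound 3 to compound 4 (within the scatter), and beside the earlier step on the core of compound 1, this change reads the same on both cores: the same change on two cores in this assay, no change at the digits printed (within the scatter) from compound 1 to compound 2 and a number 1.5 percentage points higher (within the scatter) from compound 3 to compound 4, 1.5 percentage points apart, within the scatter of two such steps. Likewise, 3-hydroxyphenyl in place of 2-hydroxyphenyl gives a number 1.5 percentage points higher from compound 2 to compound 4 (within the scatter), and this change also reads the same on both cores: the same change on two cores in this assay, no change at the digits printed (within the scatter) from compound 1 to compound 3 and a number 1.5 percentage points higher (within the scatter) from compound 2 to compound 4, 1.5 percentage points apart, within the scatter of two such steps. The remaining step, 4-hydroxyphenyl in place of 2-hydroxyphenyl, gives a number 1.5 percentage points higher from compound 1 to compound 4 (within the scatter), so every comparison here is between steps too small to stand out from the scatter, which shows that these hydroxyl moves leave the read-out unchanged on these cores but not that a change with a real effect on one core would carry over to another.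

All four compounds keep the furan-2-yl group and two hydroxyphenyl groups, so the compounds shown leave open whether any change other than moving a hydroxyl would alter the read-out. An amine or a carboxylic acid in place of a hydroxyl, or another ring such as thiophene in place of the furan-2-yl group, could answer that question.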